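This account rests on a few compounds, and the source may have more. Where it says the series, first, only, none or still open, it means among the compounds named here.

In a functional assay on U-87MG ATCC cells (Homo sapiens) for cytotoxicity, read by MTT assay, with a stated time of 48 h (a higher number here means a weaker inhibitor, a lower number a stronger inhibitor), compound 1 (`C/C(=N\NC(=S)Nc1ccccc1I)c1ccccn1`) gives 6.1 nM as the highest of three numbers. Compound 2 (`C/C(=N\NC(=S)Nc1ccccc1Cl)c1ccccn1`) has chloro in place of iodo and gives 2.6 nM while compound 3 (`C/C(=N\NC(=S)Nc1ccccc1)c1ccccn1`) has hydrogen in its place and gives 1.4 nM here. Compound 4 (`CC(=NNC(=S)Nc1ccccc1I)c1ccccn1`) brings the two compounds have the same atoms and bonds; at least one stereo element is drawn with a configuration in one of them and without one in the other: 1 of 1 stereo elements differ; a double bond is drawn E in compound 1 and without a configuration in compound 4 and nothing more: the two compounds have the same atoms and bonds, and a double bond is drawn E in compound 1 and without a configuration in compound 4. The measured steps, a 2.3-fold lower number from compound 1 to compound 2 (0.37 log units; beyond the scatter) and a 4.4-fold lower number from compound 1 to compound 3 (0.64 log units; beyond the scatter) and a 1.9-fold lower number from compound 2 to compound 3 (0.27 log units; within the scatter) all swap a group on an aromatic carbon, a change absent here, so no step beyond the scatter is expected in either direction. The estimated change is no change at the digits printed from compound 1 to compound 4 (within the scatter) and no more. Compound 4 is expected at 6.1 nM with an estimated range of 3 nM to 12 nM in this assay.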

Compound 4, half-maximal inhibitory concentration: 6.1 nM
Compound 4: middle estimate and measured number agree at the digits printed; the range from low to high includes it.
By their numbers in this assay, from the lowest: compounds 3 and 2 (each within the scatter of the next); then compounds 1 and 4 (each within the scatter of the next).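

In this assay, the only difference between the two drawings lies at the double bond, and the result is no change at the digits printed from compound 1 to compound 4 (within the scatter). The earlier steps shown here all changed the group on the aromatic carbon, whereas this pair keeps the iodo group and tests only how the configuration is drawn. The pair therefore shows no separate effect of drawn configuration, and its one distinguishing feature is this: the fact that one of compounds 1 and 4 is drawn with a defined configuration and the other without, at the place where they differ.

As far as these compounds go, whether compound 4 is a single form or a mixture stays open, so the true effect of configuration cannot be read. Also open, from the compounds shown here alone, is how a methoxy group or an amine in place of iodo would compare.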